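A few compounds are considered here, and "the series" means these few. Any claim that something is new, unique, unknown or untested is made for them only; others in the source may bear on it.

Compound 1 `O=C(/C=C/c1ccccn1)c1nc2ccccc2s1`: > 100000 nM
Compound 2 `O=C(/C=C/c1ccc(Br)cc1)c1nc2ccccc2[nH]1`: 19600 nM
Compound 3 `O=C(/C=C/c1cccc(Cl)c1)c1nc2ccccc2s1`: > 100000 nM

These compounds were tested in a functional assay on HCT-116 cells (Homo sapiens) for antiproliferative activity, read by MTT assay, with a stated time of 48 h; a higher number here means a weaker inhibitor, a lower number a stronger inhibitor. Compound 1 gives > 100000 nM, which is a limit of the assay and not a number. Compound 3 gives > 100000 nM, which is also a limit. Within the data shown here, compound 2, at 19600 nM, therefore holds the only actual number in the set, and the other two results sit at the limit of > 100000 nM in this assay, at which 2 of the 3 values shown sit.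

Compound 4 `O=C(/C=C/c1ccccc1)c1nc2ccccc2[nH]1` departs from compound 2 in a single place: hydrogen in place of bromo on an aromatic carbon. This puts hydrogen in place of bromo on an aromatic carbon, para to a large group. Among the measured compounds shown here, no measured pair shows what this swap does, so the expectation rests on compound 2 at 19600 nM. The expectation also takes in the two limits reached by compound 1 and compound 3. A small move toward weaker inhibition is expected, perhaps hardly beyond the usual scatter, and the result could also reach the limit of this assay. The expected change is a 1.5-fold higher number from compound 2 to compound 4 (0.18 log units; within the scatter). For compound 4 the estimated value is 30000 nM, with an expected range of 10000 nM to 90000 nM.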

Compound 4, half-maximal inhibitory concentration: 200 nM
Compound 4: middle estimate off by 150-fold (2.18 log units), on the high side, outside the stated range (below it).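

In this assay, putting hydrogen in place of bromo on this aromatic carbon gives a 98-fold lower number from compound 2 to compound 4 (1.99 log units; beyond the scatter). This is the first measured step among these compounds, and it shows that this one place, para to a large group, can strongly change the result. Since a single bromine atom is the only difference between the two structures, bromo is clearly not needed here for activity, and the compound with hydrogen is the stronger inhibitor of this pair.

Why this swap has so large an effect stays open, as does whether bromo is unusual or any group here would weaken inhibition, which a fluoro, a methoxy or an amine at this place could help to show. Few actual numbers are available for comparison: the limit of > 100000 nM in this assay, at which 2 of the 4 values shown sit.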